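Replacing a dimethylphenyl with a methylpyridyl on a shared core

A few compounds are considered here, and "the series" means these few. Any claim that something is new, unique, unknown or untested is made for them only; others in the source may bear on it.

Compound 3 `Cc1ccc(Nc2cc(N3CCNCC3)nc3ccnn23)c(C)c1` reaches only a limit in an assay on isolated protein for inhibition of Dipeptidyl peptidase 9 (Homo sapiens) (on this read-out higher numbers stand for weaker inhibition and lower numbers for stronger inhibition), giving > 100000 nM. Compound 2 `Fc1ccc(Nc2cc(N3CCNCC3)nc3ccnn23)c(F)c1` likewise stops at a limit in this assay, with > 100000 nM. Compound 1 `Cc1ccnc(Nc2cc(N3CCC[C@@H](N)C3)nc3ccnn23)c1`, which carries the 4-methylpyridin-2-yl group on a different amine, also reports a limit in this assay, > 100000 nM. The step that the two limits leave unreadable from compound 2 to compound 3 cannot be read because the limit of > 100000 nM in this assay, at which 3 of the 3 values shown sit, holds every value shown. Compound 4 `Cc1ccnc(Nc2cc(N3CCNCC3)nc3ccnn23)c1` differs from compound 3 by 4-methylpyridin-2-yl in place of 2,4-dimethylphenyl on a nitrogen on an aromatic ring. For the measured compounds named here, no measured step bears on this change with a readable size. Compound 4 is therefore expected to stay at the limit as well, with an estimated 150000 nM (range 50000 nM to 500000 nM). The step that the limit leaves unreadable from compound 3 to compound 4 is expected to lie within the scatter.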

Compound 4, half-maximal inhibitory concentration: > 100000 nM
Compound 4 ended at the assay's limit; the forecaster's own chance of this, stated with the estimate: 85%; the middle value lies beyond the limit too.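

No new step can be read between compound 4 and compound 1, compound 2 or compound 3, because all values stop at one limit: the limit of > 100000 nM in this assay, at which 4 of the 4 values shown sit.

The compounds shown leave open how strongly any of them inhibits in this assay, and what 4-methylpyridin-2-yl in place of 2,4-dimethylphenyl changes.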